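Adding Chlorine to a Triazole-Linked Aryl Sulfonamide

The compounds below may be only part of what the source reports. "The series", "measured", "known", "first", "only" and "open" are said of these compounds alone.

Of the compounds shown here, two built on a shared core have been measured. Compound 1 `Cc1cccc(-n2cc(-c3ccccc3NS(=O)(=O)c3c[nH]c(=O)[nH]c3=O)nn2)c1` gives 3510 nM in a functional assay on SGC-7901 cells (Homo sapiens) for antiproliferative activity, read by MTT assay, with a stated time of 24 h; a higher number here means a weaker inhibitor, a lower number a stronger inhibitor. Compound 2 `O=c1[nH]cc(S(=O)(=O)Nc2ccc(-c3cn(-c4ccccc4)nn3)cc2)c(=O)[nH]1` gives 18800 nM in this assay, which is the highest of the two numbers; its nearest neighbour is compound 1, whose lower number lies beyond the usual scatter of repeated measurements. Compounds 1 and 2 differ in more than one place. Only their two values can be set side by side, and no single structural cause can be read from them.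

Compound 3 `O=c1[nH]cc(S(=O)(=O)Nc2ccc(-c3cn(-c4ccc(Cl)cc4)nn3)cc2)c(=O)[nH]1` is the next compound to be measured. It differs from compound 2 in one place: chloro in place of hydrogen on an aromatic carbon. The chlorine sits on an aromatic carbon of a six-membered aromatic ring of carbon only, para to a large group. Among the compounds with values here, no measured pair shows this change, so its effect has to be anticipated rather than read off.

The expected step is a 1.7-fold lower number from compound 2 to compound 3 (0.23 log units; within the scatter), a modest move toward a lower number that may not pass beyond the scatter. Compound 3 is estimated at 11000 nM, with a range from 3500 nM to 35000 nM.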

Compound 3, half-maximal inhibitory concentration: 1830 nM
Estimate against measurement, compound 3: 6.0-fold (0.78 log units) above; measured number outside the range, below it.
By their numbers in this assay, from the lowest: compounds 3 and 1 (each within the scatter of the next); then compound 2.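

In this assay, the change from phenyl to 4-chlorophenyl gives a 10-fold lower number from compound 2 to compound 3 (1.01 log units; beyond the scatter), a large step beyond the scatter. It shows that this position, on an aromatic carbon of a six-membered aromatic ring of carbon only and para to a large group, is one where chloro in place of hydrogen, a single added heavy atom, goes with a clear change in the antiproliferative reading. Compounds 1 and 2 differ in more than one place and could not show this, so this pair provides the first effect in the series that can be tied to one structural change, although nothing available here accounts for its size.

On these data alone, it remains open whether the step is particular to chloro or would also appear with another group at this position, such as fluoro, bromo, methyl, methoxy or an amine. Also open, as far as these compounds go, is whether chloro would give a step of similar size elsewhere on this ring, or on the core of compound 1, since a single pair cannot establish a trend.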